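A few compounds are considered here, and "the series" means these few. Any claim that something is new, unique, unknown or untested is made for them only; others in the source may bear on it.

Measured in an ADME assay on Vero cells (Chlorocebus sabaeus) for cytotoxicity, read by resazurin assay, with a stated time of 24 h; a lower number here means that less compound is tolerated, a higher number that more compound is tolerated:

Compound 1 `CCCCO[C@@H]1C=CC(=O)[C@@H](COC(=O)C(C)(C)C)O1` gives 42500 nM
Compound 2 `CCCCCCO[C@@H]1C=CC(=O)[C@@H](COC(=O)C(C)(C)C)O1` gives 4800 nM
Compound 3 `CC(=O)OC[C@H]1O[C@H](OCCC(C)C)C=CC1=O` gives 19800 nM

Compound 3 holds the middle place of the three, with compound 1 reading higher and compound 2 lower. The next structure is compound 4 `CC(C)CCO[C@@H]1C=CC(=O)[C@@H](COC(=O)C(C)(C)C)O1`, and the change leading to it is tert-butyl in place of methyl on a carbonyl carbon with tert-butyl in place of methyl on a carbonyl carbon. Among the measured compounds shown here, no measured step covers this change directly. For the measured compounds named here, the one step available, an 8.9-fold lower number from compound 1 to compound 2 (0.95 log units; beyond the scatter), alters the ether chain and not this place, so it bears on the question only indirectly. It does show that, among compounds carrying tert-butyl, the ether chain moves the number strongly. Compound 4 keeps the ether chain of compound 3 while sharing tert-butyl with compound 1 and compound 2, so its number is expected to stay in the same region. The expected change, a 1.4-fold lower number from compound 3 to compound 4 (0.15 log units; within the scatter), is a slight move to a lower number and nothing beyond the scatter. Compound 4 is estimated at 14000 nM with an expected range from 6000 nM to 30000 nM in this measurement.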

Compound 4, half-maximal cytotoxic concentration: 36000 nM
Compound 4: the middle estimate sits 2.6-fold (0.41 log units) below what was measured; the whole stated range lies below it.
By their numbers in this assay, from the lowest: compound 2; then compounds 3, 4 and 1 (each within the scatter of the next, the first and the last beyond it).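

In this assay, replacing methyl with tert-butyl on the carbonyl carbon, that is, acetoxy with ((tert-butyl)carbonyl)oxy, gives a 1.8-fold higher number from compound 3 to compound 4 (0.26 log units; within the scatter) while the ether chain stays unchanged, so at this position the change does not move the number beyond the scatter. The ether chain remains the place that separates these compounds, since a 7.5-fold higher number from compound 2 to compound 4 (0.88 log units; beyond the scatter) while the smaller chain change gives a 1.2-fold lower number from compound 1 to compound 4 (0.07 log units; within the scatter) and leaves the two compounds within the scatter of each other. Nothing measured here offers an explanation for these results.

The compounds shown leave open whether the same methyl to tert-butyl change would stay within the scatter on the longer ether chain of compound 2. They also leave open how a phenyl group or an amine would read at the carbonyl carbon.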